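Adding a Methyl on the Ring Double Bond of Compound 1

The source may report more compounds than this note shows. Statements on the series, on what has been measured and on what is new or still open speak of the compounds shown alone.

Compound 1 `CCOC(=O)c1cnc(C(F)(F)F)nc1NN1C(=O)C=C(C)C1=O` is one of two measured members of this small series. In a functional assay on Jurkat cells for inhibition of nuclear factor NF-kappa-B complex (Homo sapiens) (a higher number here means a weaker inhibitor, a lower number a stronger inhibitor), compound 1 gives 1000 nM. Its companion compound 2 `CCOC(=O)c1cnc(C(C)(C)C)nc1NN1C(=O)C=C(C)C1=O` carries tert-butyl in place of trifluoromethyl on an aromatic carbon, and in this assay compound 2 gives 1000 nM. The step of no change at the digits printed from compound 1 to compound 2 (within the scatter) lies within the scatter, so compound 1 stands level with compound 2 on the numbers at hand.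

Compound 3 `CCOC(=O)c1cnc(C(F)(F)F)nc1NN1C(=O)C(C)=C(C)C1=O` differs from compound 1 by methyl in place of hydrogen on a double-bonded ring carbon. For the measured compounds named here, no measured step touches the five-membered ring; the only measured step, no change at the digits printed from compound 1 to compound 2 (within the scatter), altered a group on the aromatic ring and showed nothing beyond the scatter. There is thus no ground to expect a shift in this assay in either direction, and compound 3 is expected to stay level with compound 1, a step of no change at the digits printed from compound 1 to compound 3 (within the scatter). The estimate for compound 3 is 1000 nM, with a range from 400 nM to 2500 nM.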

Compound 3, half-maximal inhibitory concentration: 10000 nM
Compound 3: the middle estimate sits 10-fold (1.00 log units) below what was measured; the whole stated range lies below it.
By their numbers in this assay, from the lowest: compounds 1 and 2 (each within the scatter of the next); then compound 3.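

In this assay, the double-bonded ring carbon of the five-membered ring proves sensitive to substitution: methyl in place of hydrogen gives a 10-fold higher number from compound 1 to compound 3 (1.00 log units; beyond the scatter), whereas the earlier step on the aromatic carbon gave no change at the digits printed from compound 1 to compound 2 (within the scatter). For the compounds shown here, compound 3 is thus the only compound here separated from the others beyond the scatter, and the added methyl moves it toward weaker inhibition. Nothing available explains why this methyl has this effect.

The compounds shown leave open whether the loss belongs to methyl alone or would also follow from another group on this carbon, such as ethyl, chlorine or an amine. They also leave open whether the same methyl would give a step of similar size with tert-butyl in place of trifluoromethyl on the aromatic carbon.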